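Cytotoxicity series on Raji cells: a hydroxymethyl analogue

The source may report more compounds than this note shows. Statements on the series, on what has been measured and on what is new or still open speak of the compounds shown alone.

Measured so far in an ADME assay on Raji cells (Homo sapiens) for cytotoxicity, read by luminescence, with a stated time of 72 h; on this read-out higher numbers stand for an effect only at larger amounts of compound and lower numbers for an effect already at smaller amounts:
- compound 1 `CCOC(=O)c1c(-c2cccc(OCc3ccccc3)c2)[nH]c2cc(OC)ccc2c1=O`; compound 1 reaches only the assay limit, > 21500 nM
- compound 2 `CCOC(=O)c1c(-c2cccc(Oc3ccccc3)c2)[nH]c2cc(OC)ccc2c1=O`; compound 2 reaches only the assay limit, > 21500 nM
- compound 3 `CCOC(=O)c1c(-c2cccc(C(F)(F)F)c2)[nH]c2cc(OC)ccc2c1=O`; compound 3 reaches only the assay limit, > 21500 nM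

Compound 3 stands where all three measured compounds stand, at the limit of > 21500 nM in this assay, at which 3 of the 3 values shown sit. The steps a step that the two limits leave unreadable from compound 1 to compound 2, a step that the two limits leave unreadable from compound 1 to compound 3 and a step that the two limits leave unreadable from compound 2 to compound 3 therefore give no readable size. Compound 4 `CCOC(=O)c1c(-c2cccc(CO)c2)[nH]c2cc(OC)ccc2c1=O` differs from compound 3 by hydroxymethyl in place of trifluoromethyl on an aromatic carbon. Among the compounds with values here, no measured step covers a change of this kind, and none of the measured steps is readable, so no step beyond the scatter is expected in this assay. Compound 4 is expected to give 30000 nM, in the range 15000 nM to 90000 nM, which means an expected step that the limit leaves unreadable from compound 3 to compound 4.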

Compound 4, half-maximal effective concentration: > 21500 nM
Compound 4: a limit, no number; the forecaster's own chance of this, stated with the estimate: 80%; the middle value lies beyond the limit too.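

Compound 4 joins compound 1, compound 2 and compound 3 at a limit rather than a number, so none of its steps to them can be read: the limit of > 21500 nM in this assay, at which 4 of the 4 values shown sit. The compounds shown leave open how far beyond that limit any of the four lies, and which change, if any, alters the read-out.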